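A few compounds are considered here, and "the series" means these few. Any claim that something is new, unique, unknown or untested is made for them only; others in the source may bear on it.

Three compounds sharing one core have been measured in a functional assay on NCI-H460 cells (Homo sapiens) for antiproliferative activity, read by MTT assay, with a stated time of 72 h; a lower number here means a stronger inhibitor, a higher number a weaker inhibitor:

compound 1 `COc1cc2c(Oc3ccc(Nc4nccc5[nH]cc(-c6ccc(F)cc6)c(=O)c45)cc3F)ccnc2cc1OCCO` gives 2000 nM
compound 2 `CC(C)(O)COc1ccc2c(Oc3ccc(Nc4nccc5[nH]cc(-c6ccc(F)cc6)c(=O)c45)cc3F)ccnc2c1` gives 3200 nM
compound 3 `COCCOc1cc2nccc(Oc3ccc(Nc4nccc5[nH]cc(-c6ccc(F)cc6)c(=O)c45)cc3F)c2cc1OC` gives 3000 nM

For the measured compounds named here, compound 2 at 3200 nM stands within the scatter of both compound 1 and compound 3 , so these three values set no order among the compounds. Compound 4 `CC(O)COc1ccc2c(Oc3ccc(Nc4nccc5[nH]cc(-c6ccc(F)cc6)c(=O)c45)cc3F)ccnc2c1` follows from compound 2 by one structural change: hydrogen in place of methyl on a saturated chain carbon bound to an oxygen on a saturated carbon and two saturated chain carbons. This is hydrogen in place of methyl on a saturated chain carbon bound to an oxygen on a saturated carbon and two saturated chain carbons, which turns 2-hydroxy-2-methylpropoxy into 2-hydroxypropoxy. Going by the values given here, no measured step makes this same change. The only one available, a 1.5-fold higher number from compound 1 to compound 3 (0.18 log units; within the scatter), also concerns a methyl and a hydrogen, but on an oxygen and not on a chain carbon, so it bears on the change only loosely. It gives no reason to look for a shift beyond the scatter in this assay in either direction. The expected change is small, with an estimated 1.1-fold lower number from compound 2 to compound 4 (0.06 log units; within the scatter) that remains within the scatter. The estimate for compound 4 is 2800 nM within an expected range of 1400 nM to 5500 nM around it.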

Compound 4, half-maximal inhibitory concentration: 3400 nM
For compound 4 the middle estimate is 1.2-fold (0.08 log units) below the measured one, within the range that was stated.
By their numbers in this assay, from the lowest: compounds 1, 3, 2 and 4 (each within the scatter of the next).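

In this assay, for the compounds shown here, the change on the chain gives a 1.1-fold higher number from compound 2 to compound 4 (0.03 log units; within the scatter), the first measured step at this saturated chain carbon. It shows that 2-hydroxy-2-methylpropoxy and 2-hydroxypropoxy cannot be told apart here: the earlier step concerned a methyl on an oxygen, and a methyl lost from the chain carbon itself also leaves the number within the scatter. Nothing available offers an explanation for this result.

The compounds shown leave open whether an amine or a carboxylic acid in place of the hydroxyl, or a longer chain, would move the number beyond the scatter. As each of the four values lies within the scatter of the next, they also leave open which structural change would shift the result in this assay at all.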